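The compounds below may be only part of what the source reports. "The series", "measured", "known", "first", "only" and "open" are said of these compounds alone.

In a functional assay on cells (leukaemia cell line, Homo sapiens) for inhibition, read by sulforhodamine B assay, with a stated time of 48 h (a lower number here means a stronger inhibitor of growth, a higher number a weaker inhibitor of growth), compound 1 `O=S(=O)(Nc1ccc(F)c(Cl)c1)c1ccc(-c2cnc(C3CC3)o2)cc1` gives 260 nM and compound 2 `Cc1cc(Cl)ccc1NS(=O)(=O)c1ccc(-c2cnc(C3CC3)o2)cc1` gives 277 nM with a gap of a 1.1-fold higher number from compound 1 to compound 2 (0.03 log units; within the scatter) between them. Compound 3 `O=S(=O)(Nc1ccc(I)c(Cl)c1)c1ccc(-c2cnc(C3CC3)o2)cc1` at 1010 nM has the highest number of the three.

The next structure is compound 4 `Cc1cc(F)cc(NS(=O)(=O)c2ccc(-c3cnc(C4CC4)o3)cc2)c1`, which keeps the shared core and changes only the group on a sulfonamide nitrogen: 3-fluoro-5-methylphenyl in place of 3-chloro-4-iodophenyl on a sulfonamide nitrogen is the whole difference. Going by the values given here, two measured steps bear on this change: a 3.9-fold higher number from compound 1 to compound 3 (0.59 log units; beyond the scatter) and a 3.6-fold higher number from compound 2 to compound 3 (0.56 log units; beyond the scatter) are both modest. Among the compounds with values here, compound 3 is the only measured compound with iodo, and that group leaves in compound 4. Within the data shown here, no measured compound carries 3-fluoro-5-methylphenyl, so the read-across is indirect and the range stays wide.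

A modest move to a lower number in this assay is expected, an estimated 2.9-fold lower number from compound 3 to compound 4 (0.46 log units; beyond the scatter) in size. That would put the new value in the region of compound 1 at 260 nM and not at the level seen for iodo. The estimate for compound 4 is 350 nM with an expected range of 130 nM to 900 nM in this assay.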

Compound 4, concentration for 50% growth inhibition: 138 nM
Beside the measured number, compound 4's estimate is 2.5-fold (0.40 log units) above it, within the range that was stated.
By their numbers in this assay, from the lowest: compounds 4, 1 and 2 (each within the scatter of the next); then compound 3.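

In this assay, going by these compounds alone, taking out 3-chloro-4-iodophenyl on the sulfonamide nitrogen in favour of 3-fluoro-5-methylphenyl gives a 7.3-fold lower number from compound 3 to compound 4 (0.86 log units; beyond the scatter), so compound 3 stays the one compound set apart from the others. The new group cannot be separated from the other two groups at this place, with a 2.0-fold lower number from compound 2 to compound 4 (0.30 log units; within the scatter) and a 1.9-fold lower number from compound 1 to compound 4 (0.28 log units; within the scatter), and this holds although compound 4 is the first compound here without chloro on that ring, so chloro is not needed for values at this level among the compounds shown. No evidence on hand bears on why the iodo compound differs.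

Still open, from the compounds shown here alone, is whether bromo in place of iodo tracks compound 3 or compound 4. Also open, going by these compounds, is how an amine, a carboxylic acid or a longer alkyl chain on this ring would read in this assay.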